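A few compounds are considered here, and "the series" means these few. Any claim that something is new, unique, unknown or untested is made for them only; others in the source may bear on it.

Working notes on the benzylthiazole amide series.

Three members of the series are in hand. Compound 1 `COc1ccc(C(=O)Nc2ncc(Cc3cccc(C(F)(F)F)c3)s2)cc1` carries a trifluoromethyl on the benzyl ring and a single methoxy on the benzamide; in an assay on microsomes for inhibition of acyl-CoA desaturase 1 (Mus musculus), with a stated time of 60 min (a higher number here means a weaker inhibitor, a lower number a stronger inhibitor), compound 1 is recorded as "not determined" (no result reported). Compound 2 `COc1cc(C(=O)Nc2ncc(Cc3cccc(C(F)(F)F)c3)s2)ccc1OCCO` keeps the trifluoromethyl and adds the hydroxyethoxy group to the benzamide; in this assay compound 2 gives 3 nM. Compound 3 `COc1ccc(C(=O)Nc2ncc(Cc3cccc(F)c3)s2)cc1OCCO` keeps that benzamide and carries a fluorine on the benzyl ring instead; in this assay compound 3 gives 2 nM. The numbers for compound 3 and compound 2 sit within the usual scatter of each other, so nothing separates them; compound 1 contributes no number.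

The next member, compound 4 `COc1ccc(C(=O)Nc2ncc(Cc3ccc(Cl)c(Cl)c3)s2)cc1OCCO`, differs from compound 3 in one place: 3,4-dichlorophenyl in place of 3-fluorophenyl on a saturated chain carbon bound to an aromatic carbon. Going by the values given here, no step between two measured compounds reads on this exchange. What the two measured numbers do show is that the benzyl substituent could be swapped from trifluoromethyl to fluorine without a shift beyond the scatter, so a third aryl pattern is expected to land in the same region.

For compound 4 in this assay the estimate is 3 nM, expected between 1 nM and 10 nM. The step from compound 3 to compound 4 is thus expected to be a 1.5-fold higher number from compound 3 to compound 4 (0.18 log units; within the scatter), not beyond the scatter.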

Compound 4, half-maximal inhibitory concentration: 0.8 nM
Estimate against measurement, compound 4: 3.8-fold (0.57 log units) above, and the stated range ends above it.
By their numbers in this assay, from the lowest: compound 4; then compounds 3 and 2 (each within the scatter of the next).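

In this assay, going by these compounds alone, the exchange of 3-fluorophenyl for 3,4-dichlorophenyl on a saturated chain carbon bound to an aromatic carbon gives a 2.5-fold lower number from compound 3 to compound 4 (0.40 log units; beyond the scatter), the only step so far that reads on a single change. This shows that the number still responds to the aryl group at this position, even among compounds already low in the assay, and that the position has not reached a plateau where aryl patterns are interchangeable. The exchange removes one fluorine and brings in two chlorines in a single move, so the step belongs to the whole 3,4-dichlorophenyl group, and nothing measured on these compounds gives a reason for it.

Open, going by these compounds, is how much of the step each chlorine carries, which 3-chlorophenyl and 4-chlorophenyl at the same place would separate, and whether a pyridine ring in place of the dichlorinated ring would hold the number. Also open, on these data alone, is how far the benzamide side matters with the 3,4-dichlorophenyl group in place, for instance with a carboxylic acid or an amine at the end of the hydroxyethoxy chain instead of its hydroxyl.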